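From 2-methylphenyl to 4-methylphenyl: a cytotoxicity estimate

This account rests on a few compounds, and the source may have more. Where it says the series, first, only, none or still open, it means among the compounds named here.

Measured compounds:
- compound 1 `Cc1cc(-c2cccc(F)c2)cc(C)c1Oc1cc(N)nc(Nc2ccc(C#N)cc2)n1` with 24700 nM
- compound 2 `Cc1ccccc1-c1cc(C)c(Oc2cc(N)nc(Nc3ccc(C#N)cc3)n2)c(C)c1` with 25600 nM

In a toxicity assay on MT4 cells (Homo sapiens) for cytotoxicity, read by MTT assay (on this read-out higher numbers stand for lower toxicity in this test and lower numbers for higher toxicity in this test), compound 2 stands level with compound 1, the two numbers lying within the scatter of each other. Compound 3 `Cc1ccc(-c2cc(C)c(Oc3cc(N)nc(Nc4ccc(C#N)cc4)n3)c(C)c2)cc1` carries 4-methylphenyl in place of 2-methylphenyl on an aromatic carbon and is otherwise the same as compound 2. Among the measured compounds shown here, the one measured step at this place (a 1.0-fold higher number from compound 1 to compound 2 (0.02 log units; within the scatter)) exchanged 3-fluorophenyl for 2-methylphenyl and stayed within the scatter. For the measured compounds named here, no compound with 4-methylphenyl has a number yet, so the expectation rests on that single step. No change beyond the scatter is expected in either direction in this assay, the expected step being small (a 1.0-fold lower number from compound 2 to compound 3 (0.01 log units; within the scatter)). Compound 3 is estimated at 25000 nM (expected range 12000 nM to 50000 nM).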

Compound 3, half-maximal cytotoxic concentration: 10000 nM
The estimate for compound 3 lay 2.5-fold (0.40 log units) above the measured number; the measured number lies below the stated range.
By their numbers in this assay, from the lowest: compound 3; then compounds 1 and 2 (each within the scatter of the next).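

In this assay, the exchange of 2-methylphenyl for 4-methylphenyl gives a 2.6-fold lower number from compound 2 to compound 3 (0.41 log units; beyond the scatter), so two groups with the same atoms, joined differently, are told apart at this place. Against 3-fluorophenyl, 4-methylphenyl gives a 2.5-fold lower number from compound 1 to compound 3 (0.39 log units; beyond the scatter), whereas the only earlier step here, between 3-fluorophenyl and 2-methylphenyl, stayed within the scatter; the read-out at this place therefore does respond to the aromatic group it carries, and here toward higher toxicity in this test. Nothing at hand bears on why the two groups differ.

The compounds shown leave open whether this lower number belongs to 4-methylphenyl alone. They also leave open whether an amine or a carboxylic acid in place of its methyl would give a similar number.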